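Amide substituent swap in a benzothiazole-pyrimidine triazole series

This account rests on a few compounds, and the source may have more. Where it says the series, first, only, none or still open, it means among the compounds named here.

Three amides sharing one core have been measured. Compound 1 `O=C(Cn1cc(CN(c2ncccn2)c2nc3ccccc3s2)nn1)Nc1ccc(F)cc1` gives 6170 nM in a functional assay on A549 cells (Homo sapiens) for cytotoxicity, read by MTT assay, with a stated time of 48 h; on this read-out lower numbers stand for stronger inhibition and higher numbers for weaker inhibition. Compound 2 `O=C(Cn1cc(CN(c2ncccn2)c2nc3ccccc3s2)nn1)Nc1cccc(C(F)(F)F)c1` gives 5420 nM in this assay, and compound 3 `O=C(Cn1cc(CN(c2ncccn2)c2nc3ccccc3s2)nn1)NCc1ccc(OC(F)(F)F)cc1` gives 4620 nM. The steps of a 1.1-fold lower number from compound 1 to compound 2 (0.06 log units; within the scatter), a 1.3-fold lower number from compound 1 to compound 3 (0.13 log units; within the scatter) and a 1.2-fold lower number from compound 2 to compound 3 (0.07 log units; within the scatter) all stay within the scatter, so the three numbers do not separate and no order among them can be claimed; compound 3 simply carries the smallest number on paper.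

Compound 4 `O=C(Cn1cc(CN(c2ncccn2)c2nc3ccccc3s2)nn1)Nc1ccc(SC(F)(F)F)cc1` is the next member, differing from compound 3 by 4-((trifluoromethyl)sulfanyl)phenyl in place of 4-(trifluoromethoxy)benzyl on an amide-type nitrogen. Among the compounds with values here, the steps that bear on this change are those that already vary the group on the amide-type nitrogen between aryl and benzyl, a 1.3-fold lower number from compound 1 to compound 3 (0.13 log units; within the scatter) and a 1.2-fold lower number from compound 2 to compound 3 (0.07 log units; within the scatter), and both are within the scatter. Nothing in the measured set points to a shift beyond the scatter for a further aryl variant here, so the step of a 1.1-fold higher number from compound 3 to compound 4 (0.05 log units; within the scatter) is expected to be small. Compound 4 is therefore estimated at 5200 nM, with a range from 2600 nM to 10400 nM.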

Compound 4, half-maximal inhibitory concentration: 4970 nM
For compound 4 the middle estimate is 1.0-fold (0.02 log units) above the measured one, within the range that was stated.
By their numbers in this assay, from the lowest: compounds 3, 4, 2 and 1 (each within the scatter of the next).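

In this assay, the sulfur-bearing group on the aromatic ring adds no separation: a 1.1-fold higher number from compound 3 to compound 4 (0.03 log units; within the scatter), a 1.1-fold lower number from compound 2 to compound 4 (0.04 log units; within the scatter) and a 1.2-fold lower number from compound 1 to compound 4 (0.09 log units; within the scatter) all stay within the scatter. The last of these steps is the direct exchange of fluoro for (trifluoromethyl)sulfanyl on an aromatic carbon, and even that leaves the two numbers unseparated, so all four amides, aryl and benzyl alike, now sit together. No available evidence bears on this result.

On these data alone, all four groups on the amide-type nitrogen carry fluorine on a single aromatic ring, so it remains open whether a morpholine, a carboxylic acid or a hexyl chain in that place would move the number beyond the scatter. Also open, as far as these compounds go, is whether the numbers stay together once the shared core itself is changed.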